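The compounds below may be only part of what the source reports. "The series", "measured", "known", "first", "only" and "open" are said of these compounds alone.

Measured so far in the series:

Compound 1 `COc1ccc(/C=C/C(=O)c2ccc(OC)c3c2OC(C)(C)C=C3)c(F)c1`: in a functional assay on HepG2 cells (Homo sapiens) for antiproliferative activity, read by MTT assay, with a stated time of 24 h (on this read-out higher numbers stand for weaker inhibition and lower numbers for stronger inhibition), compound 1 gives 7560 nM.
Compound 2 `COc1ccc(C(=O)/C=C/c2ccsc2)c2c1C=CC(C)(C)O2`: in this assay compound 2 gives > 10000 nM, which is a limit of the assay and not a number (the limit of > 10000 nM in this assay, at which 1 of the 3 values shown sits).
Compound 3 `COc1ccc(C(=O)/C=C/c2ccccn2)c2c1C=CC(C)(C)O2`: in this assay compound 3 gives 5760 nM.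

Of the two numbers, compound 3 gives the lower one, but the step of a 1.3-fold lower number from compound 1 to compound 3 (0.12 log units; within the scatter) sits within the scatter, so no order between compound 1 and compound 3 is claimed. The change from compound 1 to compound 2 reads an at least 1.3-fold higher number from compound 1 to compound 2 (0.12 log units; that floor lies within the scatter) and ends at a limit.

The next compound, compound 4 `COc1ccc(C(=O)/C=C/c2cccs2)c2c1C=CC(C)(C)O2`, differs from compound 3 only at the chain end: thiophen-2-yl in place of pyridin-2-yl on a double-bonded chain carbon bound to a double-bonded chain carbon. The measured step that bears on it most directly runs the other way, an at least 1.7-fold lower number from compound 2 to compound 3 (0.23 log units; that floor lies within the scatter), from a thiophene at the same place to the pyridine, and ends in a number only on the pyridine side. Thiophen-2-yl is not the same ring as thiophen-3-yl, so that step is a guide, not a repeat. In this assay the step of a 1.6-fold higher number from compound 3 to compound 4 (0.19 log units; within the scatter) is therefore expected to go toward a higher number, with a real chance that only a limit is returned. Compound 4 is estimated at 9000 nM, within 4000 nM to 20000 nM.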

Compound 4, half-maximal inhibitory concentration: > 10000 nM
Compound 4: only a limit was reported; the forecaster's own chance of this, stated with the estimate: 40%; at least 1.1-fold (0.04 log units) between middle value and limit.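

In this assay compound 4 gives a limit and not a number, so at this place, on a double-bonded chain carbon bound to a double-bonded chain carbon, thiophen-2-yl now ends at a limit just as thiophen-3-yl does, and the attachment point of the thiophene does not bring a number back within the compounds shown. The change from the pyridine reads an at least 1.7-fold higher number from compound 3 to compound 4 (0.23 log units; that floor lies within the scatter), and the change from the substituted phenyl reads an at least 1.3-fold higher number from compound 1 to compound 4 (0.12 log units; that floor lies within the scatter); each is only a floor, so neither separates thiophen-2-yl from the other group by more than the scatter, although the true gaps may be larger. The step between the two thiophene attachments cannot be read, because both compounds sit at the same limit: the limit of > 10000 nM in this assay, at which 2 of the 4 values shown sit.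

Across the compounds shown, no group at this place is separated from compound 3 by a step printed as beyond the scatter, so it remains open whether this position can move the read-out clearly at all. Also open, as far as these compounds go, is whether pyridin-3-yl, a 4-aminophenyl ring or a chain end bearing a carboxylic acid would give a number clearly apart from compound 3.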